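The source may report more compounds than this note shows. Statements on the series, on what has been measured and on what is new or still open speak of the compounds shown alone.

Measured so far in a physicochemical assay for solubility, at pH 7.4; on this read-out higher numbers stand for higher solubility and lower numbers for lower solubility:

- compound 1 `Cc1cc(NC(=O)Nc2ccccc2N)c2ccccc2n1` gives 51800 nM
- compound 2 `Cc1cc(NC(=O)Nc2ccc(N)cc2)c2ccccc2n1` gives 18500 nM
- compound 3 `Cc1cc(NC(=O)Nc2ccc(C(=O)O)cc2)c2ccccc2n1` gives 9300 nM

Compound 3 sits within the usual scatter of compound 2, and both numbers lie under that of compound 1. Compound 4 `Cc1cc(NC(=O)Nc2ccc(Cl)cc2)c2ccccc2n1` carries chloro in place of carboxy on an aromatic carbon at the same place. The closest guide is the swap of amino for carboxy there, a 2.0-fold lower number from compound 2 to compound 3 (0.30 log units; within the scatter), which stayed within the scatter. Putting 4-aminophenyl in place of 2-aminophenyl gave a 2.8-fold lower number from compound 1 to compound 2 (0.45 log units; beyond the scatter), a modest step. Among the measured compounds shown here, no chloro compound has been measured, so neither step settles the matter. A modest step is expected, a 2.3-fold lower number from compound 3 to compound 4 (0.37 log units; beyond the scatter) in this assay, towards a lower number. The estimate for compound 4 is 4000 nM (expected range 1200 nM to 10000 nM).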

Compound 4, solubility: 1400 nM
Beside the measured number, compound 4's estimate is 2.9-fold (0.46 log units) above it; measured number inside the range.
By their numbers in this assay, from the lowest: compound 4; then compounds 3 and 2 (each within the scatter of the next); then compound 1.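

At this position the groups no longer fall together: in this assay chloro stands clearly apart from carboxy (a 6.6-fold lower number from compound 3 to compound 4 (0.82 log units; beyond the scatter)) and from amino (a 13-fold lower number from compound 2 to compound 4 (1.12 log units; beyond the scatter)), whereas amino and carboxy lay within the scatter of each other. Exchanging the whole substituted phenyl group gives the widest gap in the set (a 37-fold lower number from compound 1 to compound 4 (1.57 log units; beyond the scatter)). Nothing available explains why chloro gives the lowest number here. Still open, going by these compounds, is whether fluoro, bromo or methoxy at this place would fall with chloro or with amino and carboxy. On these data alone, whether chloro on another ring carbon would give a similar step also remains open.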